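The source may hold more compounds than are shown below. What is called first, only, known or untested is meant among the compounds shown, and "the series" means these compounds.

Values in a functional assay on thoracic aorta (Rattus norvegicus, strain Wistar), with a stated time of 15 min; on this read-out lower numbers stand for an effect already at smaller amounts and higher numbers for an effect only at larger amounts of compound:

- compound 1 `Cc1ccc(OCc2ccccc2)c(C(C)NC(=O)NS(=O)(=O)c2ccc(Cl)cc2)c1`: 65300 nM
- compound 2 `Cc1ccc(S(=O)(=O)N(C)C(=O)NC(C)c2cc(C)ccc2OCc2ccccc2)cc1`: 181000 nM
- compound 3 `CC(NC(=O)N(C)S(=O)(=O)c1ccc(Cl)cc1)c1ccccc1OCc1ccccc1`: 38400 nM
- compound 4 `Cc1ccc(OCc2ccccc2)c(C(C)NC(=O)N(C)S(=O)(=O)c2ccc(Cl)cc2)c1`: not yet measured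

In this assay compound 3 gives 38400 nM, within the scatter of compound 1 . Compound 2 is a higher number than compound 3 , beyond the scatter.

Compound 4 has methyl in place of hydrogen on an aromatic carbon, para to a benzyloxy group (methyl in place of hydrogen on an aromatic carbon). No measured pair differs by this change alone, so its size is not shown directly. The methyl is also present in compound 1 and compound 2 , and neither gives a number under that of compound 3 , although only compound 2 stands clear of the scatter. The expectation therefore leans on compound 1 at 65300 nM.

The expected change in this assay is small, either slightly upward or none beyond the scatter, and the estimated step is a 1.6-fold higher number from compound 3 to compound 4 (0.19 log units; within the scatter). For compound 4 the estimate is 60000 nM, with an expected range of 25000 nM to 150000 nM.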

Compound 4, half-maximal effective concentration: 142000 nM
Compound 4: middle estimate off by 2.4-fold (0.37 log units), on the low side; the range from low to high includes it.
By their numbers in this assay, from the lowest: compounds 3 and 1 (each within the scatter of the next); then compounds 4 and 2 (each within the scatter of the next).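

In this assay, methyl in place of hydrogen on the aromatic carbon para to a benzyloxy group now has a direct matched reading, a 3.7-fold higher number from compound 3 to compound 4 (0.57 log units; beyond the scatter), a modest rise that goes beyond the scatter. With that aromatic methyl in place, methyl in place of hydrogen on the amide-type nitrogen gives a 2.2-fold higher number from compound 1 to compound 4 (0.34 log units; beyond the scatter), also modest and beyond the scatter, while chloro in place of methyl on an aromatic carbon gives a 1.3-fold lower number from compound 2 to compound 4 (0.11 log units; within the scatter), which stays within the scatter. Nothing measured here accounts for these steps.

Whether the rise belongs to methyl alone stays open, since no other group at this position, such as ethyl or methoxy, appears among the compounds shown. The effect of an amine or a carboxylic acid at this position is equally unknown.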